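Adding a Methyl Group to Compound 3

This account rests on a few compounds, and the source may have more. Where it says the series, first, only, none or still open, it means among the compounds named here.

Measured values:
- compound 1 `O=C1OC[C@H](Cc2ccccc2)[C@H]1Cc1cccc(O)c1`: > 100000 nM (a limit)
- compound 2 `Cc1cccc(C[C@H]2C(=O)OC[C@@H]2Cc2ccccc2)c1`: 53000 nM
- compound 3 `Cc1ccc(C[C@H]2C(=O)OC[C@@H]2Cc2ccccc2)cc1`: 44000 nM

In a functional assay on HL-60 cells (Homo sapiens) for cytotoxicity, read by WST assay, with a stated time of 48 h (on this read-out lower numbers stand for an effect already at smaller amounts and higher numbers for an effect only at larger amounts of compound), compound 3 gives 44000 nM, within the scatter of compound 2. For compound 1, > 100000 nM is a limit of the assay and not a number. Compound 4 `Cc1ccc(C[C@H]2C(=O)OC[C@@H]2Cc2ccccc2)cc1C` has methyl in place of hydrogen on an aromatic carbon, ortho to a methyl group (methyl in place of hydrogen on an aromatic carbon). The closest guide is a 1.2-fold lower number from compound 2 to compound 3 (0.08 log units; within the scatter), which concerns methyl placement. Also relevant are an at least 1.8-fold lower number from compound 1 to compound 2 (0.27 log units; that floor lies within the scatter) and an at least 2.2-fold lower number from compound 1 to compound 3 (0.35 log units; beyond the scatter). On these steps, only a small move towards a lower number is expected in this assay, probably not beyond the scatter. The expected change is a 1.3-fold lower number from compound 3 to compound 4 (0.10 log units; within the scatter). For compound 4 the estimated value is 35000 nM, with an expected range of 15000 nM to 80000 nM.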

Compound 4, half-maximal effective concentration: 35000 nM
For compound 4 middle estimate and measured number coincide at the digits printed; the range from low to high includes it.
By their numbers in this assay, from the lowest: compounds 4, 3 and 2 (each within the scatter of the next). At a limit, above all of these: compound 1.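

In this assay, adding a methyl group on an aromatic carbon, ortho to a methyl group, gives a 1.3-fold lower number from compound 3 to compound 4 (0.10 log units; within the scatter), and the second comparison gives a 1.5-fold lower number from compound 2 to compound 4 (0.18 log units; within the scatter). Among the compounds shown here, this position therefore takes a further methyl group without a change that can be told from the scatter, which compounds with only one methyl group could not show. Nothing at hand bears on a cause for these small steps.

On these data alone, whether an amine or a carboxylic acid at this position would move the number beyond the scatter stays open.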